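Series notes: aminoalkyl substituent on the ring nitrogen

A few compounds are considered here, and "the series" means these few. Any claim that something is new, unique, unknown or untested is made for them only; others in the source may bear on it.

Measured: compound 1 `COc1cccc(-c2c(C)n(Cc3c(F)cccc3F)c(=O)n(C[C@H](N)C(C)C)c2=O)c1F` 51 nM; compound 2 `COc1cccc(-c2c(C)n(Cc3c(F)cccc3F)c(=O)n(C[C@H](NC(C)C)C3CCCC3)c2=O)c1F` 12 nM.

In an assay on HEK293 cells for binding affinity to Gonadotropin-releasing hormone receptor (Homo sapiens), read by radioligand binding (on this read-out lower numbers stand for stronger inhibition and higher numbers for weaker inhibition), compound 2 stands lowest of the two numbers; the step of a 4.3-fold lower number from compound 1 to compound 2 (0.63 log units; beyond the scatter) is beyond the scatter. Compound 3 `COc1cccc(-c2c(C)n(Cc3c(F)cccc3F)c(=O)n(C[C@@H](N)C(C)C)c2=O)c1F` is not yet measured; its change is 1-amino-2-methylpropyl in place of cyclopentyl(isopropylamino)methyl on a saturated chain carbon bound to an aromatic nitrogen. Going by the values given here, the entering group carries the same name as that of compound 1, so the step of a 4.3-fold lower number from compound 1 to compound 2 (0.63 log units; beyond the scatter) read in reverse is the only guide, and a rise of about that size is expected for compound 3, a 6.7-fold higher number from compound 2 to compound 3 (0.82 log units; beyond the scatter), with the range kept wide. Among the compounds with values here, no step in this direction has been seen. Estimate for compound 3: 80 nM (20 nM to 400 nM).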

Compound 3, inhibition constant: 973 nM
The estimate for compound 3 lay 12-fold (1.09 log units) below the measured number, outside the stated range (above it).
By their numbers in this assay, from the lowest: compound 2; then compound 1; then compound 3.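

In this assay, the name 1-amino-2-methylpropyl does not fix the number at this position: the stereocentre at the saturated chain carbon matters too, with a 19-fold higher number from compound 1 to compound 3 (1.28 log units; beyond the scatter) seen for one group, and this step can be assigned to configuration because of the following: the fact that compounds 1 and 3 differ only in the configuration as drawn
Thus an 81-fold higher number from compound 2 to compound 3 (1.91 log units; beyond the scatter) is not simply the reverse of a 4.3-fold lower number from compound 1 to compound 2 (0.63 log units; beyond the scatter) and a step at this position cannot be read from group names alone.

Open, as far as these compounds go, is whether cyclopentyl(isopropylamino)methyl depends on configuration to a similar degree. Also open, from the compounds shown here alone, is how a dimethylamino group or a carboxylic acid would read in place of the amine on this chain.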